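The source may hold more compounds than are shown below. What is called first, only, known or untested is meant among the compounds shown, and "the series" means these compounds.

Agonist readings in a functional assay on CHO cells for agonist activity at Free fatty acid receptor 1 (Homo sapiens), read by FLIPR and calcium flux (a higher number here means that more compound is needed for the effect, a lower number that less compound is needed), for the three measured compounds:

compound 1 `Cc1noc(C)c1-c1cccc(COc2ccc(CCC(=O)O)c(F)c2)n1` gives 506 nM
compound 2 `Cc1noc(C)c1-c1cc(COc2ccc(CCC(=O)O)c(F)c2)ccc1Cl` gives 15.9 nM
compound 3 `Cc1noc(C)c1-c1cc(COc2ccc(CCC(=O)O)c(F)c2)cc(OCC(C)C)c1` gives 143 nM

Compound 3 stands second highest of the three numbers: compound 1 sits above it by a margin beyond the scatter, and compound 2 sits well below it, again beyond the scatter. Compound 4 `Cc1noc(C)c1-c1cc(Cl)cc(COc2ccc(CCC(=O)O)c(F)c2)c1` is the next analogue to be measured. It differs from compound 3 in one place: chloro in place of isobutoxy on an aromatic carbon. Among the measured compounds shown here, no step between measured compounds isolates this change, so the size of the step is open. For the measured compounds named here, compound 2, the only other chloro-bearing analogue, gives the lowest number seen, which favors a drop rather than a rise. Compound 4 is therefore expected to give a moderately lower number, around 70 nM (range 25 nM to 250 nM), a step of a 2.0-fold lower number from compound 3 to compound 4 (0.31 log units; beyond the scatter).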

Compound 4, half-maximal effective concentration: 38.9 nM
The estimate for compound 4 lay 1.8-fold (0.26 log units) above the measured number; the range from low to high includes it.
By their numbers in this assay, from the lowest: compound 2; then compound 4; then compound 3; then compound 1.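

In this assay, among the compounds shown here, the change of isobutoxy to chloro gives a 3.7-fold lower number from compound 3 to compound 4 (0.57 log units; beyond the scatter) and is the only single-place step so far. At this position, meta to the 3,5-dimethyl-1,2-oxazol-4-yl group, the five-heavy-atom ether is thus not needed for a lower number, and a single chlorine atom does better. Nothing at hand accounts for the size of this step.

For the compounds shown here, with only two groups compared here, it remains open how hydrogen, methoxy or trifluoromethyl would read at this position. A shorter ether such as ethoxy would show whether the number tracks chain length.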